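Fluorophenyl to Difluorophenyl: Expected Liver Microsome Stability

The source may report more compounds than this note shows. Statements on the series, on what has been measured and on what is new or still open speak of the compounds shown alone.

Compound 1 `Cc1nc(N)nc(N[C@@H](C)c2cc3ccc(F)cn3c(=O)c2-c2ccccc2)c1C#N` was tested in an ADME assay on microsomes from liver (Mus musculus), read by LC-MS, using NADPH, with a stated time of 30 min, tested at 1 uM (on this read-out higher numbers stand for a more stable compound and lower numbers for a less stable compound), and gives 8%, a low level of remaining compound. Compound 2 `C[C@H](Nc1nc(N)nc(N)c1C#N)c1cc(=O)n2cc(F)ccc2c1-c1ccc(F)cc1` shares much of the same build but differs in the core; in this assay compound 2 gives "not determined" (no result reported), so no single number stands for it, and the step from compound 2 to compound 3 has no measured starting point. Compound 3 `C[C@H](Nc1nc(N)nc(N)c1C#N)c1cc(=O)n2cc(F)ccc2c1-c1cc(F)cc(F)c1` differs from compound 2 only in that a (3,5-difluorophenyl in place of 4-fluorophenyl on an aromatic carbon). Among the measured compounds shown here, no measured pair shows this kind of change, so nothing here tells how large a step it brings; for compound 3 no step beyond the usual scatter in this assay is expected, in either direction. For the measured compounds named here, the only number available, from compound 1 in this assay, is low. Compound 3 is therefore estimated at 12%, with a range from 2% to 35%.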

Compound 3, percent of the compound remaining: 90%
The estimate for compound 3 lay 78 percentage points below the measured number; the whole stated range lies below it.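

Among the compounds shown here, compound 3 gives 90% in this assay, but compound 2 has no reported result there, so no step between them can be read. Whether 3,5-difluorophenyl in place of 4-fluorophenyl changes the percent remaining stays open, and no measured evidence here explains the value of compound 3.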